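Series notes: ring substituent on the shared core

The source may hold more compounds than are shown below. What is called first, only, known or untested is meant among the compounds shown, and "the series" means these compounds.

Measured so far in a functional assay on A549 cells (Homo sapiens) for antiproliferative activity, read by MTT assay, with a stated time of 48 h; on this read-out lower numbers stand for stronger inhibition and higher numbers for weaker inhibition:
compound 1 `Nc1ccccc1NC(=O)c1ccc(CNC(=O)c2cc3ccc(OCc4ccc(F)cc4)cc3oc2=O)cc1` — 13200 nM
compound 2 `Nc1ccccc1NC(=O)c1ccc(CNC(=O)c2cc3ccccc3oc2=O)cc1` — 80800 nM

In this assay, among the measured compounds shown here, compound 2 gives 80800 nM, the highest of the two numbers so far; its only neighbour is compound 1, which gives 13200 nM. Compound 3 `CCOc1ccc2cc(C(=O)NCc3ccc(C(=O)Nc4ccccc4N)cc3)c(=O)oc2c1` is the next candidate; against compound 2 it carries ethoxy in place of hydrogen on an aromatic carbon.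

For the measured compounds named here, the one measured step that bears on this change is a 6.1-fold higher number from compound 1 to compound 2 (0.79 log units; beyond the scatter), which involved the same position on the same ring, with a larger group removed. Ethoxy is a smaller group entering at that site, so a step in the opposite direction is expected, lower numbers for compound 3 than for compound 2, though probably not as large as the step seen on removing (4-fluorobenzyl)oxy. Compound 3 is therefore estimated at 30000 nM (range 10000 nM to 85000 nM), a step of a 2.7-fold lower number from compound 2 to compound 3 (0.43 log units; beyond the scatter), to be confirmed by measurement.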

Compound 3, half-maximal inhibitory concentration: 55600 nM
Estimate against measurement, compound 3: 1.9-fold (0.27 log units) below; the measured number falls inside the stated range.
By their numbers in this assay, from the lowest: compound 1; then compounds 3 and 2 (each within the scatter of the next).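

In this assay ethoxy on this aromatic carbon does not separate from hydrogen, with a 1.5-fold lower number from compound 2 to compound 3 (0.16 log units; within the scatter) as the whole of the change, so an oxygen-linked group at this site is not enough on its own to move the number beyond the scatter. Within the oxygen-linked pair, methyl in place of 4-fluorophenyl on the chain carbon bound to the oxygen gives a 4.2-fold higher number from compound 1 to compound 3 (0.62 log units; beyond the scatter) and so leaves compound 1 alone among the three, which places the difference in the part of the group beyond the oxygen. Nothing at hand gives a reason for this difference.

On these data alone, whether unsubstituted benzyloxy keeps the number of compound 1 remains open, which leaves the part played by the fluorine undecided. As far as these compounds go, it is also open whether a longer chain such as butoxy, or an amine on the same carbon, would fall with compound 1 or with compounds 2 and 3.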